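Removing a methoxy group: one change, measured twice

The compounds below may be only part of what the source reports. "The series", "measured", "known", "first", "only" and "open" are said of these compounds alone.

Measured compounds in a functional assay on FM3A cells (Mus musculus) for inhibition, read by cell counting, with a stated time of 2 days; on this read-out lower numbers stand for stronger inhibition and higher numbers for weaker inhibition:

Compound 1, `C=C(Br)C(=O)Nc1cccc(-c2cn3nc(Cc4cccc(OC)c4)sc3n2)c1`, gives 1100 nM.
Compound 2, `C=C(Br)C(=O)Nc1cccc(-c2cn3nc(Cc4ccccc4)sc3n2)c1`, gives 3000 nM.
Compound 3, `COc1cccc(-c2nn3cc(-c4cccc(N)c4)nc3s2)c1`, gives 29000 nM.

Compound 1 and compound 2 differ by one change, (hydrogen in place of methoxy on an aromatic carbon), and this produced a 2.7-fold higher number from compound 1 to compound 2 (0.44 log units; beyond the scatter). Compound 4, `Nc1cccc(-c2cn3nc(-c4ccccc4)sc3n2)c1`, has not yet been measured; it differs from compound 3 by hydrogen in place of methoxy on an aromatic carbon, the same change at the same kind of place. The difference between the core of compound 1 and the core of compound 3 is not broken down here. Compound 3 already gives the highest number of the three, so the step from compound 3 to compound 4 is expected to be a 2.4-fold higher number from compound 3 to compound 4 (0.38 log units; beyond the scatter), resting on the earlier step from compound 1 to compound 2. Compound 4 is therefore estimated at 70000 nM, likely between 30000 nM and 200000 nM.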

Compound 4, half-maximal inhibitory concentration: 14000 nM
For compound 4 the middle estimate is 5.0-fold (0.70 log units) above the measured one; the whole stated range lies above it.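

In this assay, putting hydrogen in place of methoxy produces a 2.1-fold lower number from compound 3 to compound 4 (0.32 log units; beyond the scatter), so the number falls on this core, whereas it rose on the core of compound 1. The two results point in opposite directions, and the gap between them is larger than repeat measurements would explain: the same change on two cores in this assay, a 2.7-fold higher number (0.44 log units; beyond the scatter) from compound 1 to compound 2 and a 2.1-fold lower number (0.32 log units; beyond the scatter) from compound 3 to compound 4, 5.6-fold (0.75 log units) apart, beyond the scatter of two such steps. The effect of this change therefore did not carry from one core to the other, but two pairs cannot show which part of the cores matters or how the change would behave on a third core.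

Going by these compounds, it remains open how other groups, such as a fluorine or a hydroxyl, would behave in place of methoxy on either core.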